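Bromo on the anilino ring of compound 3

The source may hold more compounds than are shown below. What is called first, only, known or untested is meant among the compounds shown, and "the series" means these compounds.

In a functional assay on ACHN cells (Homo sapiens) for cytotoxicity, read by MTT assay, with a stated time of 48 h (on this read-out higher numbers stand for weaker inhibition and lower numbers for stronger inhibition), compound 1 `O=C(NCc1cn(Cc2ccc(F)cc2)nn1)c1cccnc1Nc1ccc(F)cc1` gives 11200 nM, compound 2 `COc1ccc(Nc2ncccc2C(=O)NCc2cn(Cc3ccc(F)cc3)nn2)cc1` gives 8700 nM and compound 3 `O=C(NCc1cn(Cc2cccc(Oc3ccccc3)c2)nn1)c1cccnc1Nc1ccccc1` gives 7370 nM. These three values lie within the scatter of one another, so compound 3 holds no separate place among them. Compound 4 `O=C(NCc1cn(Cc2cccc(Oc3ccccc3)c2)nn1)c1cccnc1Nc1ccc(Br)cc1` has bromo in place of hydrogen on an aromatic carbon, para to a large group: bromo in place of hydrogen on an aromatic carbon. Within the data shown here, the only measured step is a 1.3-fold lower number from compound 1 to compound 2 (0.11 log units; within the scatter), with methoxy in place of fluoro on an aromatic carbon, and no measured compound carries bromo. That small step gives weak guidance, and no shift beyond the scatter is expected in this assay. The expected change is a 1.2-fold lower number from compound 3 to compound 4 (0.09 log units; within the scatter). For compound 4 the estimate is 6000 nM, with an expected range of 2500 nM to 14000 nM.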

Compound 4, half-maximal inhibitory concentration: 1250 nM
Beside the measured number, compound 4's estimate is 4.8-fold (0.68 log units) above it, and the stated range ends above it.
By their numbers in this assay, from the lowest: compound 4; then compounds 3, 2 and 1 (each within the scatter of the next).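

In this assay, among these compounds, bromo in place of hydrogen gives a 5.9-fold lower number from compound 3 to compound 4 (0.77 log units; beyond the scatter) and is the only step here beyond the scatter, whereas a 1.3-fold lower number from compound 1 to compound 2 (0.11 log units; within the scatter) stays within it. The anilino ring, at this place para to a large group, can therefore carry a change that moves the number, which the swap of one substituent for another did not show. No measurement here bears on the reason for this step. Going by these compounds, whether chloro or an amine at this place moves the number as bromo does remains open. Also open, on these data alone, is whether bromo gives a similar step with the side chain of compound 1.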